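The source may report more compounds than this note shows. Statements on the series, on what has been measured and on what is new or still open speak of the compounds shown alone.

Measured compounds: compound 1 `CCCN(CCC(F)(F)F)Cc1c(C(F)(F)F)nc2n(-c3c(C)cc(C)cc3C)c(Cl)cn12`, compound 2 `C=CCN(CCC)Cc1c(C(F)(F)F)nc2n(-c3c(C)cc(C)cc3C)c(Cl)cn12`, compound 3 `Cc1cc(C)c(-n2c(Cl)cn3c(CN4CCCC4c4ccccc4)c(C(F)(F)F)nc23)c(C)c1`.

In an assay on cells for displacement of a labelled ligand from corticotropin-releasing factor receptor 1 (Homo sapiens), with a stated time of 100 min (a higher number here means a weaker inhibitor, a lower number a stronger inhibitor), compound 1 gives 12 nM and compound 2 gives 4.5 nM. For compound 3 the assay reports only a limit, > 7000 nM; this is the line (the limit of > 7000 nM in this assay, at which 1 of the 3 values shown sits), and compound 3 is the only one of the three that sits there. The steps of an at least 580-fold higher number from compound 1 to compound 3 (2.76 log units; beyond the scatter) and an at least 1500-fold higher number from compound 2 to compound 3 (3.19 log units; beyond the scatter) are both large. Compound 4 `Cc1cc(C)c(-n2c(Cl)cn3c(CN4CCC(C)CC4)c(C(F)(F)F)nc23)c(C)c1` differs from compound 3 by 4-methylpiperidin-1-yl in place of 2-phenylpyrrolidin-1-yl on a saturated chain carbon bound to an aromatic carbon. For the measured compounds named here, no measured step runs between two such ring amines; the two large steps only show that the acyclic amines of compound 1 and compound 2 give far lower numbers than the 2-phenylpyrrolidin-1-yl of compound 3. A lower number than the limit is expected, but with wide uncertainty: for compound 4 the estimate is 300 nM, between 30 nM and 5000 nM, meaning an expected step of an at least 23-fold lower number from compound 3 to compound 4 (1.36 log units; beyond the scatter).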

Compound 4, inhibition constant: 3200 nM
The estimate for compound 4 lay 11-fold (1.03 log units) below the measured number; measured number inside the range.
By their numbers in this assay, from the lowest: compound 2; then compound 1; then compound 4. At a limit, above all of these: compound 3.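

At this position, the saturated chain carbon bound to an aromatic carbon, a ring amine without a phenyl group also stays far from the acyclic amines: a 710-fold higher number from compound 2 to compound 4 (2.85 log units; beyond the scatter) and a 270-fold higher number from compound 1 to compound 4 (2.43 log units; beyond the scatter). Between the two ring amines, 4-methylpiperidin-1-yl in place of 2-phenylpyrrolidin-1-yl gives an at least 2.1-fold lower number from compound 3 to compound 4 (0.33 log units; beyond the scatter), and that size is only a bound. Compound 3 stands at a limit, not at a number: the limit of > 7000 nM in this assay, at which 1 of the 4 values shown sits.

As far as these compounds go, the true size of that step stays open. Also open, from the compounds shown here alone, is whether the ring itself or its methyl group sets the number, and whether unsubstituted piperidin-1-yl or morpholin-4-yl would sit nearer compound 2 or compound 4.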